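Aryl urea series: ethyl replaces trifluoromethylsulfanyl, cytotoxicity outlook

This account rests on a few compounds, and the source may have more. Where it says the series, first, only, none or still open, it means among the compounds named here.

Measured compounds:
- Compound 1 `Cc1ccc(NC(=O)Nc2cc(C)nc3ccccc23)cc1`: > 25000 nM
- Compound 2 `Cc1cc(NC(=O)Nc2ccc(F)cc2)c2ccccc2n1`: > 25000 nM
- Compound 3 `Cc1cc(NC(=O)Nc2ccc(SC(F)(F)F)cc2)c2ccccc2n1`: 13000 nM

In an ADME assay on HEK293 cells (Homo sapiens) for cytotoxicity, with a stated time of 72 h (a lower number here means that less compound is needed, a higher number that more compound is needed for the effect), compound 1 reaches only a limit, > 25000 nM. Compound 2 likewise sits at a limit, > 25000 nM. Among the compounds with values here, compound 3 is the one member of the set with an actual number, 13000 nM, so within this assay it stands alone as the compound that is readable. The two steps leading to it, an at least 1.9-fold lower number from compound 1 to compound 3 (0.28 log units; that floor lies within the scatter) and an at least 1.9-fold lower number from compound 2 to compound 3 (0.28 log units; that floor lies within the scatter), are known only as floors because the limit of > 25000 nM in this assay, at which 2 of the 3 values shown sit, caps the starting values; the step that the two limits leave unreadable from compound 1 to compound 2 cannot be read at all.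

Compound 4 `CCc1ccc(NC(=O)Nc2cc(C)nc3ccccc23)cc1` is not yet measured. The change is ethyl in place of (trifluoromethyl)sulfanyl on an aromatic carbon. This undoes the kind of change seen in the step from compound 1 to compound 3, since compound 1 carries a methyl where compound 4 carries an ethyl, and compound 1 sat at the limit. The expected step is therefore upward, a 1.9-fold higher number from compound 3 to compound 4 (0.28 log units; within the scatter), with a fair chance that this assay again reports only a limit. For compound 4 the estimated value is 25000 nM, in a range from 10000 nM to 60000 nM.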

Compound 4, half-maximal effective concentration: 16000 nM
Estimate against measurement, compound 4: 1.6-fold (0.19 log units) above; the range from low to high includes it.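

In this assay, compound 4 gives a second readable number on the ring position para to a large group, so a readable value no longer belongs to the (trifluoromethyl)sulfanyl group alone. Ethyl, with fewer heavy atoms and no hydrogen-bond acceptor, separates from that group only by a 1.2-fold higher number from compound 3 to compound 4 (0.09 log units; within the scatter), which shows no difference between the two at this place. The other two steps, an at least 1.5-fold lower number from compound 2 to compound 4 (0.19 log units; that floor lies within the scatter) and an at least 1.5-fold lower number from compound 1 to compound 4 (0.19 log units; that floor lies within the scatter), remain floors because the starting values are capped: the limit of > 25000 nM in this assay, at which 2 of the 4 values shown sit.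

Going by these compounds, how an amine, a carboxylic acid or a longer chain such as butyl would read at this position stays open. On these data alone, the true size of the step between methyl and ethyl also stays open.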